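A few compounds are considered here, and "the series" means these few. Any claim that something is new, unique, unknown or untested is made for them only; others in the source may bear on it.

Compound 1 `COc1ccc(N(C)c2nc(C)nc3ccccc23)cc1OCCN` carries on its shared core an aminoethoxy side chain and is tested in a functional assay on A549 cells (Homo sapiens) for inhibition, read by MTT assay, with a stated time of 48 h (on this read-out higher numbers stand for weaker inhibition and lower numbers for stronger inhibition), where compound 1 gives 122 nM. Among the two measured compounds this is the highest number, so compound 1 is the weaker inhibitor of the pair. The other measured compound, compound 2 `C[Se]c1ccc(N(C)c2nc(C)nc3ccccc23)cc1C`, gives 2 nM in this assay, a far lower number, and the gap between the two lies beyond the usual scatter. Among the compounds with values here, compound 2 differs from compound 1 in more than one place, so no single structural step connects them.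

Compound 3 `COc1ccc(N(C)c2nc(C)nc3ccccc23)cc1OCCCCC[Se]C#N` has not yet been measured. It keeps the core and the aromatic oxygen of compound 1 but alters the side chain: a group of 6 heavy atoms (4 carbon, 1 nitrogen, 1 selenium; no ring) in place of one nitrogen atom, on a saturated chain carbon, two bonds along the chain from an oxygen on an aromatic ring. Nothing in the measured pair isolates this change, so its effect cannot be read off directly. Starting from compound 1 alone, the move to compound 3 is expected to bring a modest shift toward a lower number, though a result within the scatter would not surprise. Compound 3 is therefore estimated at 40 nM, with a range from 8 nM to 200 nM. The expected step is a 3.1-fold lower number from compound 1 to compound 3 (0.48 log units; beyond the scatter).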

Compound 3, half-maximal inhibitory concentration: 2440 nM
Compound 3: the middle estimate sits 61-fold (1.79 log units) below what was measured; the whole stated range lies below it.
By their numbers in this assay, from the lowest: compound 2; then compound 1; then compound 3.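

At this place on the side chain, on a saturated chain carbon, two bonds along the chain from an oxygen on an aromatic ring, replacing the amino group with the group of 6 heavy atoms (4 carbon, 1 nitrogen, 1 selenium; no ring) gives, in this assay, a 20-fold higher number from compound 1 to compound 3 (1.30 log units; beyond the scatter), which means weaker inhibition. Within the data shown here, this is the first single-place comparison, and it shows that the end of this side chain is not a neutral spot: what sits there can move the number well beyond the usual scatter, and this particular exchange moves it toward weaker inhibition. Nothing measured here bears on why the number rises.

The exchange changes several things at once, removing the amino group, extending the chain and adding both a selenium atom and a triple bond, so these two compounds cannot say which of those changes carries the step. A longer chain ending in an amine, or a short chain ending in a nitrile, would help separate the contribution of chain length from that of the group at its end.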